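This account rests on a few compounds, and the source may have more. Where it says the series, first, only, none or still open, it means among the compounds named here.

Compound 2, with the structure `O=C(O)CCc1ccc(OCc2nnc(C(=O)Nc3cccc(F)c3)s2)cc1`, is the reference point for this step. In a functional assay on CHO cells for agonist activity at Free fatty acid receptor 1 (Homo sapiens), read by calcium flux (a higher number here means that more compound is needed for the effect, a lower number that less compound is needed), compound 2 gives 1190 nM, the lowest of the two numbers available, although its nearest neighbour is not far away: compound 1, with the structure `Cc1cccc(NC(=O)c2nnc(COc3ccc(CCC(=O)O)cc3)s2)c1`, gives in this assay 1770 nM. Going by the values given here, the one measured step between them, a 1.5-fold lower number from compound 1 to compound 2 (0.17 log units; within the scatter), a fluoro in place of a methyl on the aromatic ring of the anilide, lies within the scatter, so the two compounds cannot be ordered.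

Compound 3, with the structure `O=C(O)CCc1ccc(OCc2nnc(C(=O)Nc3ccc(F)c(F)c3)s2)cc1`, is to be measured next. It differs from compound 2 by fluoro in place of hydrogen on an aromatic carbon, so the anilide ring carries a second fluoro next to the first. Among the compounds with values here, the only measured step that bears on this change is the exchange on the same ring, a 1.5-fold lower number from compound 1 to compound 2 (0.17 log units; within the scatter), which stayed within the scatter. Within the data shown here, no measured step adds a second substituent to this ring. Compound 3 is therefore expected to move little, with an estimated step of a 1.2-fold lower number from compound 2 to compound 3 (0.08 log units; within the scatter) in this assay. For compound 3 the estimated value is 1000 nM, with a range from 450 nM to 2500 nM.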

Compound 3, half-maximal effective concentration: 580 nM
Compound 3: middle estimate off by 1.7-fold (0.24 log units), on the high side, and the stated range covers the measured number.
By their numbers in this assay, from the lowest: compound 3; then compounds 2 and 1 (each within the scatter of the next).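

In this assay, going by these compounds alone, placing a fluoro ortho to the existing fluoro and para to a large group gives a 2.1-fold lower number from compound 2 to compound 3 (0.31 log units; beyond the scatter), the first step to lie beyond the scatter, so this ring position can change the number where the earlier exchange of methyl for fluoro could not be read. Replacing 3-methylphenyl with 3,4-difluorophenyl on the amide-type nitrogen gives a 3.1-fold lower number from compound 1 to compound 3 (0.48 log units; beyond the scatter), which sets compound 3 apart from both compound 1 and compound 2, although those two cannot be ordered against each other. Nothing on hand offers an explanation for these steps.

Going by these compounds, it remains open whether a phenyl ring carrying only the new fluoro would give a similar number, or whether the step depends on both fluoro groups being present. On these data alone, it is equally open whether the step is particular to fluoro, or whether chloro, methoxy, nitrile or trifluoromethyl at this place would lower the number as well.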